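Fluoro for isopropyl on the anilino ring of compound 2

A few compounds are considered here, and "the series" means these few. Any claim that something is new, unique, unknown or untested is made for them only; others in the source may bear on it.

Compound 1 `O=C(COc1ccc(C(=O)/C=C/c2ccccc2Br)cc1)N[C@H]1CCOC1=O`: 15300 nM in a functional assay on MCF7 cells (Homo sapiens) for antiproliferative activity, read by MTT assay, with a stated time of 72 h; a lower number here means a stronger inhibitor, a higher number a weaker inhibitor
Compound 2 `CC(C)c1ccc(NCC(=O)N[C@H]2CCOC2=O)cc1`: > 64000 nM in this assay, a limit of the assay
Compound 3 `O=C(CNc1ccc(Cl)cc1Cl)N[C@H]1CCOC1=O`: > 64000 nM in this assay, a limit of the assay

Compound 2 stands at a limit in this assay, not at a number; the same holds for compound 3, so that (the limit of > 64000 nM in this assay, at which 2 of the 3 values shown sit). Only compound 1 gives a measured value there. Compound 4 `O=C(CNc1ccc(F)cc1)N[C@H]1CCOC1=O` differs from compound 2 by fluoro in place of isopropyl on an aromatic carbon. Within the data shown here, no step between two measured compounds is known for this change, so no direction can be read from the data. Compound 4 is expected to sit again at the limit of this assay, estimated near 70000 nM, within 30000 nM to 160000 nM. The expected step that the limit leaves unreadable from compound 2 to compound 4 is estimated to stay within the scatter.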

Compound 4, half-maximal inhibitory concentration: > 64000 nM
Compound 4 gave a limit, no number; the forecaster's own chance of this, stated with the estimate: 80%; the middle value is on the limit's open side.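

Compound 2 and compound 4 both stand at a limit, not at a number, so no step between them can be read: the limit of > 64000 nM in this assay, at which 3 of the 4 values shown sit.

The compounds shown leave open how fluoro and isopropyl on this aromatic carbon compare in this assay.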